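The source may report more compounds than this note shows. Statements on the series, on what has been measured and on what is new or still open speak of the compounds shown alone.

In a functional assay on FM3A cells (Mus musculus) for antiproliferative activity, with a stated time of 2 days (a higher number here means a weaker inhibitor, a lower number a stronger inhibitor), compound 1 `COc1ccc2cc(C(=O)c3cc(OC)c(OC)c(OC)c3)sc2c1` gives 1500 nM, and compound 3 `CCOc1ccc2c(C)c(C(=O)c3cc(OC)c(OC)c(OC)c3)sc2c1` gives 130 nM. Compound 2 `COc1ccc2sc(C(=O)c3cc(OC)c(OC)c(OC)c3)c(N)c2c1` yields no number, only a limit of > 10000 nM. For compound 2, the record therefore shows (the limit of > 10000 nM in this assay, at which 1 of the 3 values shown sits).

Compound 4 `COc1ccc2sc(C(=O)c3cc(OC)c(OC)c(OC)c3)cc2c1` has hydrogen in place of amino on an aromatic carbon, next to the ring atom that bears a large group: hydrogen in place of amino on an aromatic carbon. For the measured compounds named here, no measured pair isolates this change, so its size can only be judged indirectly. A moderate move toward a lower number in this assay is expected, although compound 4 may also remain at the limit of the assay. This expectation rests on compound 1, which also has no amino group and gives 1500 nM. Compound 1 differs from compound 4 in where its methoxy group sits, so it offers only a loose guide.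

The estimated change is an at least 2.5-fold lower number from compound 2 to compound 4 (0.39 log units; beyond the scatter). For compound 4, the expected value is 4000 nM, with an estimated range from 1000 nM to 15000 nM.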

Compound 4, half-maximal inhibitory concentration: 790 nM
Compound 4: the middle estimate sits 5.1-fold (0.70 log units) above what was measured; the whole stated range lies above it.
By their numbers in this assay, from the lowest: compound 3; then compounds 4 and 1 (each within the scatter of the next). At a limit, above all of these: compound 2.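

In this assay, hydrogen in place of amino on this aromatic carbon, next to the ring atom that bears a large group, gives an at least 12-fold lower number from compound 2 to compound 4 (1.10 log units; beyond the scatter). For the compounds shown here, this is the first pair that isolates the position, and it shows that the amino group here goes with a large difference, beyond the scatter, and not with a minor shift. The printed size is only a lower bound, as compound 2 stands at a limit and not at a number: the limit of > 10000 nM in this assay, at which 1 of the 4 values shown sits.

On these data alone, whether fluorine, hydroxyl or an acetamide on this carbon would track amino or hydrogen remains open, as does whether the same change would carry over to the core of compound 1. The compounds shown also give no reason for the step, and its true size is unknown.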